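Swapping the Trifluoromethyl Position on a Shared Core

The compounds below may be only part of what the source reports. "The series", "measured", "known", "first", "only" and "open" are said of these compounds alone.

Compound 1 `Oc1ccccc1-c1cc(-c2ccc(C(F)(F)F)cc2)cc(-c2ccccc2O)n1` and compound 2 `Oc1ccc(-c2cc(-c3cccc(C(F)(F)F)c3)cc(-c3ccccc3O)n2)cc1` carry a trifluoromethylphenyl group on a shared core. In a functional assay on DU-145 cells (Homo sapiens) for inhibition (on this read-out lower numbers stand for stronger inhibition and higher numbers for weaker inhibition), compound 1 gives > 50000 nM, which is a limit of the assay rather than a number. In this assay compound 2 gives > 50000 nM, likewise a limit. Both results sit at the same point: the limit of > 50000 nM in this assay, at which 2 of the 2 values shown sit. Compound 3 `Oc1ccc(-c2cc(-c3ccc(C(F)(F)F)cc3)cc(-c3ccccc3O)n2)cc1` differs from compound 2 only in 4-(trifluoromethyl)phenyl in place of 3-(trifluoromethyl)phenyl on an aromatic carbon. Within the data shown here, no measured step covers this change, so nothing beyond the usual scatter is expected, and a limit again seems most likely. Compound 3 is expected to give 50000 nM in this assay, estimated between 20000 nM and 150000 nM. That expectation amounts to a step of a number no higher from compound 2 to compound 3 (the limit leaves the size open).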

Compound 3, half-maximal inhibitory concentration: > 50000 nM
Compound 3 was reported as a limit; the forecaster's own chance of this, stated with the estimate: 80%; the middle value lies on the limit itself.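

Compound 3 gives > 50000 nM as a limit of the assay, like compound 1 and compound 2, so no step among these compounds can be read. Still open, going by these compounds, is which change to the shared core, if any, would give a real number in this assay at all.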